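The source may hold more compounds than are shown below. What is called first, only, known or untested is meant among the compounds shown, and "the series" means these compounds.

Compound 1 `COc1c(O)cc(-c2coc3cc(O)cc(O)c3c2=O)cc1CC=C(C)C` carries the highest number of the three compounds measured in a functional assay on MDA-MB-231 cells (Homo sapiens) for cytotoxicity (a lower number here means that less compound is needed, a higher number that more compound is needed for the effect), where compound 1 gives 77000 nM. Compound 2 `C=C(C)/C=C/c1cc(-c2coc3cc(O)cc(O)c3c2=O)cc(O)c1OC` gives 13000 nM in this assay, and compound 3 `COc1c(CC=C(C)C)cc([C@@H]2CC(=O)c3c(O)cc(O)cc3O2)cc1CC=C(C)C`, built on a different core, gives 21600 nM. For the measured compounds named here, the only step between two measured compounds that differ in one place is a 5.9-fold lower number from compound 1 to compound 2 (0.77 log units; beyond the scatter); it swaps one group on an aromatic carbon and says nothing about the oxygen that is changed here. Compound 4 `COc1cc(-c2coc3cc(O)cc(O)c3c2=O)cc(CC=C(C)C)c1OC` differs from compound 1 in this way: methyl in place of hydrogen on an oxygen on an aromatic ring. Going by the values given here, no measured pair isolates this change, and the values of compound 1 and compound 3 differ in more than one place, so they cannot be read as a single step. The account therefore expects the step from compound 1 to compound 4 in this assay to be small, most likely within the scatter, with a modest downward tilt at most, as a 1.3-fold lower number from compound 1 to compound 4 (0.11 log units; within the scatter). The estimate for compound 4 in this assay is 60000 nM, expected to lie between 20000 nM and 150000 nM.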

Compound 4, half-maximal effective concentration: 49400 nM
Beside the measured number, compound 4's estimate is 1.2-fold (0.08 log units) above it; low and high end bracket the measured number.
By their numbers in this assay, from the lowest: compounds 2 and 3 (each within the scatter of the next); then compounds 4 and 1 (each within the scatter of the next).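

In this assay, methyl in place of hydrogen on this oxygen gives a 1.6-fold lower number from compound 1 to compound 4 (0.19 log units; within the scatter), so at this place the hydroxy and the methoxy cannot be told apart by their numbers. The other step from the same compound, on an aromatic carbon, is a 5.9-fold lower number from compound 1 to compound 2 (0.77 log units; beyond the scatter) and is printed as beyond the scatter; among the two single-place changes shown, only that one moves the number by more than repeated measurements would. Nothing at hand bears on why hydroxy to methoxy at this oxygen leaves the two numbers indistinguishable.

Going by these compounds, it remains open whether a larger group on this oxygen, such as an ethyl, a longer chain or a chain ending in a carboxylic acid, would also stay within the scatter, and whether an amine in place of the hydroxy would. On these data alone, it is equally open whether the same methyl on the corresponding oxygen of compound 2, which carries the 3-methylbuta-1,3-dien-1-yl group, would give a step of similar size.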